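A few compounds are considered here, and "the series" means these few. Any claim that something is new, unique, unknown or untested is made for them only; others in the source may bear on it.

Compound 1 `CCC(=O)NCCC(=O)c1cc(OC)ccc1N` gives 0.24% in an assay for inhibition of Nitric oxide synthase, inducible (Homo sapiens), read by scintillation counting, with a stated time of 30 min, tested at 1 mM; a higher number here means more inhibition at the concentration tested (going by the name of the read-out), a lower number less inhibition.
Compound 2 `CCCC(=O)NCCC(=O)c1cc(OC)ccc1N` gives 7.35% in this assay.
Compound 3 `CNC(=S)NCCC(O)c1cc(Cl)ccc1N` gives 22.1% in this assay.

Compound 4 `CCNC(=S)NCCC(O)c1cc(Cl)ccc1N` has not yet been measured in this assay. It differs from compound 3 by methyl in place of hydrogen on a saturated chain carbon bound to an amide-type nitrogen. The same kind of change is seen between compound 1 and compound 2, which differ by methyl in place of hydrogen on a saturated chain carbon, two bonds along the chain from a carbonyl carbon; there the carbon sits two bonds along the chain from a carbonyl carbon, whereas in compound 4 it is bound to an amide-type nitrogen. That earlier step gave a number 7.1 percentage points higher from compound 1 to compound 2 (within the scatter). The difference between the core of compound 1 and the core of compound 3 is not broken down here. Compound 3 stands highest of the three measured values, beyond the scatter from both others. From compound 3 to compound 4 a step like the earlier one is expected: a number 4.9 percentage points higher from compound 3 to compound 4 (within the scatter). For the measured compounds named here, this rests on the single measured instance of this kind of change, a number 7.1 percentage points higher from compound 1 to compound 2 (within the scatter), which stayed within the scatter. Compound 4 is therefore estimated at 27%, between 12% and 42%.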

Compound 4, a percentage reported as inhibition, at one concentration (the size of the read-out at that concentration, not a potency): 60.4%
Estimate against measurement, compound 4: 33.4 percentage points below, outside the stated range (above it).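

Turning methylamino into ethylamino gives a number 38.3 percentage points higher from compound 3 to compound 4 (beyond the scatter) in this assay. The change therefore does not carry over with a fixed size from one core to the other: the same change on two cores in this assay, a number 7.1 percentage points higher (within the scatter) from compound 1 to compound 2 and a number 38.3 percentage points higher (beyond the scatter) from compound 3 to compound 4, 31.2 percentage points apart, beyond the scatter of two such steps. For the compounds shown here, with only one pair on each core, this does not show whether the gap follows from the difference between the cores or from the different place of the added methyl, nor whether the larger step would recur on any other core.

The compounds shown leave open whether a propyl group or a longer chain in place of the ethyl would raise the number further or lower it. They also leave open what an amine or a carboxylic acid at that place would do.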